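From 4-Methylphenyl to Indolyl on a Shared Core

A few compounds are considered here, and "the series" means these few. Any claim that something is new, unique, unknown or untested is made for them only; others in the source may bear on it.

Compound 1 `COc1cc(-c2cc3nccc(-c4cc(OC)c(OC)c(OC)c4)n3n2)cc(OC)c1OC`: > 10000 nM (a limit of the assay)
Compound 2 `COc1cc(-c2ccnc3cc(-c4ccc(C)cc4)nn23)cc(OC)c1OC`: 21 nM

Both compounds were tested in a functional assay on B16-F0 cells (Mus musculus) for inhibition, read by CCK-8 assay, with a stated time of 48 h; a lower number here means a stronger inhibitor, a higher number a weaker inhibitor. Among the compounds with values here, compound 2 gives 21 nM, and this is the only actual number available so far.

The entry for compound 1, > 10000 nM, is a limit of the assay and not a number.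

Compound 3 `COc1cc(-c2ccnc3cc(-c4ccc5cc[nH]c5c4)nn23)cc(OC)c1OC` has not yet been measured. It keeps the core of compound 2 and carries 1H-indol-6-yl in place of 4-methylphenyl on an aromatic carbon. The exchange sits on a five-membered aromatic ring with 2 nitrogen, part of a fused or bridged system of two rings. The entering group retains a six-membered aromatic ring of carbon only and adds a five-membered aromatic ring with 1 hetero atom.

Within the data shown here, no measured pair of compounds shows what a change at this place does, so the expectation rests on compound 2 at 21 nM alone. No change beyond the usual scatter is expected in this assay, and the expected step is a 1.2-fold higher number from compound 2 to compound 3 (0.08 log units; within the scatter). For compound 3 the estimated value is 25 nM, within an expected range of 6 nM to 120 nM.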

Compound 3, half-maximal inhibitory concentration: 55 nM
Estimate against measurement, compound 3: 2.2-fold (0.34 log units) below; the measured number falls inside the stated range.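

In this assay, within the data shown here, replacing 4-methylphenyl with 1H-indol-6-yl gives a 2.6-fold higher number from compound 2 to compound 3 (0.42 log units; beyond the scatter), the first measured change at this place and a modest one that lies beyond the usual scatter. It shows that this aromatic carbon, on the five-membered aromatic ring with 2 nitrogen, accepts the larger two-ring group at a modest cost, and compound 3 still reads 55 nM. Nothing measured among the compounds shown accounts for the size or direction of this step.

The exchange adds the five-membered aromatic ring and the hydrogen-bond donor together, so these compounds leave open which of the two goes with the higher number, or whether the loss of the 4-methyl group contributes instead. A 1-methyl-1H-indol-6-yl group, which keeps both rings of the indole but has a methyl in place of the hydrogen on its nitrogen, would bear on that question, as would a plain phenyl group for the part played by the methyl.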